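Removing the gem-dimethyl group from a lactam substituent

A few compounds are considered here, and "the series" means these few. Any claim that something is new, unique, unknown or untested is made for them only; others in the source may bear on it.

This account follows one change in lipophilicity within a small set sharing a common core. In a physicochemical assay for lipophilicity, using the shake flask method, in phosphate buffer, measured as octanol-water partition, with a stated time of 30 min, at pH 7.4 (a higher number here means a more lipophilic compound, a lower number a more polar compound), compound 1 `CC1(C)CC(=O)N(c2cnc(NCc3c(F)ccc4c3CCO4)n3cnnc23)C1` gives 2, the lowest of the three numbers measured. Compound 2 `Cc1ncccc1-c1cnc(NCc2c(F)ccc3c2CCO3)c2cn[nH]c(=O)c12` gives 3 in this assay, a value that stands higher than that of compound 1 by an amount beyond the usual scatter. Compound 3 `Cc1ncccc1-c1cnc(NCc2c(F)ccc3c2CCO3)n2c(=O)[nH]nc12` gives 3 in this assay, likewise higher than compound 1 beyond the scatter. Compounds 2 and 3 carry a different substituent and a different core arrangement, so they offer no direct comparison for the change studied here.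

Compound 4 `O=C1CCCN1c1cnc(NCc2c(F)ccc3c2CCO3)n2cnnc12` has not yet been measured. It differs from compound 1 in one place: 2-oxopyrrolidin-1-yl in place of 4,4-dimethyl-2-oxopyrrolidin-1-yl on an aromatic carbon. The change removes two carbon atoms from the lactam ring while keeping the same ring, the same carbonyl and the same acceptor count. Going by the values given here, no measured pair shows this exact change, so the expectation rests on the loss of the 4,4-dimethyl pair alone. Such a loss is expected to lower the distribution coefficient by a moderate amount, beyond the scatter. Compound 4 is therefore estimated to give 1.1 in this assay, within a range of 0.6 to 1.6, which means an expected step of a number 0.90 log units lower from compound 1 to compound 4 (beyond the scatter).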

Compound 4, distribution coefficient: 1.3
Beside the measured number, compound 4's estimate is 0.20 log units below it, and the stated range covers the measured number.
By their numbers in this assay, from the lowest: compound 4; then compound 1; then compounds 2 and 3 (each within the scatter of the next).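

Within this assay the set now holds its first pair differing in one place, and 2-oxopyrrolidin-1-yl in place of 4,4-dimethyl-2-oxopyrrolidin-1-yl on an aromatic carbon gives a number 0.70 log units lower from compound 1 to compound 4 (beyond the scatter) as the only step read at this position. This shows that the 4,4-dimethyl pair on the lactam ring alone moves the read-out by more than the usual scatter while the shared core, the ring and the carbonyl stay the same. No measurement shown here explains the size of this step.

The compounds shown leave open whether a lactam ring carrying a single methyl group would fall between compound 1 and compound 4. They also leave open how an open-chain amide, a morpholine or a carboxylic acid would read at this position.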